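The source may hold more compounds than are shown below. What is called first, only, known or untested is meant among the compounds shown, and "the series" means these compounds.

In a functional assay on MDA-MB-231 cells (Homo sapiens) for antiproliferative activity, read by MTT assay, with a stated time of 72 h (a lower number here means a stronger inhibitor of growth, a higher number a weaker inhibitor of growth), compound 1 `Fc1ccc(-c2nss/c2=N\c2ccccc2)cc1` gives only a limit, > 10000 nM. Compound 2 `c1ccc(/N=c2\ssnc2-c2ccco2)cc1` likewise returns only a limit in this assay, > 10000 nM. For the measured compounds named here, both values sit at the limit of > 10000 nM in this assay, at which 2 of the 2 values shown sit, so compound 2 stands at the edge of what the assay resolves, and no step between measured compounds exists to draw on. Compound 3 `Cc1nss/c1=N\c1ccccc1` differs from compound 2 by methyl in place of furan-2-yl on an aromatic carbon. No shift beyond the scatter is expected. Compound 3 is estimated in this assay at 15000 nM, between 5000 nM and 50000 nM. The expected step that the limit leaves unreadable from compound 2 to compound 3 is thus essentially none.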

Compound 3, concentration for 50% growth inhibition: > 10000 nM
Compound 3 ended at the assay's limit; the forecaster's own chance of this, stated with the estimate: 80%; the middle value lies beyond the limit too.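

In this assay, for the compounds shown here, compound 2 and compound 3 both give only a limit, so no step between them can be read: the limit of > 10000 nM in this assay, at which 3 of the 3 values shown sit. The compounds shown leave open whether any change on the shared core gives this assay a readable number.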